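The compounds below may be only part of what the source reports. "The series", "measured", "known", "first", "only" and "open" are said of these compounds alone.

Measured compounds in a functional assay on HL-60 cells (Homo sapiens) for inhibition, read by MTT assay, with a stated time of 72 h; on this read-out higher numbers stand for weaker inhibition and lower numbers for stronger inhibition:
compound 1 `Cc1nc(-c2ccccc2)c(C(=O)N2CCN(c3cccc(Cl)c3Cl)CC2)o1` — 133 nM
compound 2 `COc1cc(OC)cc(N2CCN(C(=O)c3onc(C)c3-c3cccc(F)c3)CC2)c1` — 152 nM
compound 3 `COc1cccc(-c2nc(C)oc2C(=O)N2CCN(c3cccc(Cl)c3)CC2)c1` — "not active" (no number reported)

Compound 1 and compound 2 give numbers that lie within the scatter of each other in this assay, so neither can be set apart from the other; compound 3 is reported without a number. Compound 4 `CC(=O)Nc1cccc(N2CCN(C(=O)c3oc(C)nc3-c3ccccc3)CC2)c1` has not been measured. It differs from compound 1 in one place: 3-acetamidophenyl in place of 2,3-dichlorophenyl on an amine nitrogen in a ring. Among the compounds with values here, no measured pair shows this change, so its size is not known from the data. With the starting point of compound 1 at 133 nM, a modest weakening is expected, the step from compound 1 to compound 4 being estimated at a 3.0-fold higher number from compound 1 to compound 4 (0.48 log units; beyond the scatter). Compound 4 is therefore expected to give about 400 nM in this assay, between 100 nM and 3000 nM.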

Compound 4, half-maximal inhibitory concentration: 329 nM
The estimate for compound 4 lay 1.2-fold (0.08 log units) above the measured number; the measured number falls inside the stated range.
By their numbers in this assay, from the lowest: compounds 1 and 2 (each within the scatter of the next); then compound 4.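

In this assay, 3-acetamidophenyl in place of 2,3-dichlorophenyl on the amine nitrogen in the ring gives a 2.5-fold higher number from compound 1 to compound 4 (0.39 log units; beyond the scatter) and so costs only a modest step beyond the scatter. This position therefore still carries a number in the nanomolar range with a group holding a hydrogen-bond donor and acceptor. Nothing measured here explains the step.

The compounds shown do not separate the gain of the acetamido group from the loss of the two chlorines, which a plain phenyl could address. As far as these compounds go, how an amine or a carboxylic acid on this phenyl ring would read also stays open.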